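The source may hold more compounds than are shown below. What is called first, only, known or untested is meant among the compounds shown, and "the series" means these compounds.

Compound 2 `COc1ccc(CN(C(=O)Nc2ccc(C#N)cc2)n2cnnc2)cc1OC` belongs to a small set that also holds compound 1 `COc1cc(CN(C(=O)Nc2ccc(C#N)cc2)n2cnnc2)cc(OC)c1OC`, compound 3 `N#Cc1ccc(CN(C(=O)Nc2cc(C(F)(F)F)cc(C(F)(F)F)c2)n2cnnc2)cc1` and the not yet measured compound 4 `COc1ccc(CN(C(=O)Nc2ccc(Cl)cc2)n2cnnc2)cc1OC`. In a functional assay on B16-F10 cells (Mus musculus) for cytotoxicity, read by MTT assay, with a stated time of 48 h (on this read-out lower numbers stand for stronger inhibition and higher numbers for weaker inhibition), compound 1 gives 21000 nM and compound 3 gives 4510 nM. In this assay compound 2 gives > 50000 nM, which is a limit of the assay and not a number; it is the one case of the limit of > 50000 nM in this assay, at which 1 of the 3 values shown sits. The change an at least 2.3-fold higher number from compound 1 to compound 2 (0.37 log units; beyond the scatter) corresponds to hydrogen in place of methoxy on an aromatic carbon. Compound 4 differs from compound 2 by chloro in place of cyano on an aromatic carbon. Among the measured compounds shown here, no measured step shows chloro in place of cyano, so nothing here fixes the size or direction of the change in this assay. Compound 4 is therefore expected to give about 60000 nM, within 20000 nM to 200000 nM, which means an expected step that the limit leaves unreadable from compound 2 to compound 4.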

Compound 4, half-maximal inhibitory concentration: 42200 nM
Compound 4: the middle estimate sits 1.4-fold (0.15 log units) above what was measured, within the range that was stated.
By their numbers in this assay, from the lowest: compound 3; then compounds 1 and 4 (each within the scatter of the next). At a limit, above all of these: compound 2.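

In this assay, the change from 4-cyanophenyl to 4-chlorophenyl gives a measured number on a core whose cyano form reads only as a limit, a step of an at least 1.1-fold lower number from compound 2 to compound 4 (0.07 log units; that floor lies within the scatter). The step therefore shows that chloro at this position can be read on this core, but not how large the change is. Compound 2 stands at a limit, which is not a number, so the true size of the step stays unread: the limit of > 50000 nM in this assay, at which 1 of the 4 values shown sits.

As far as these compounds go, it remains open how an amine or a carboxylic acid would read at this position. From the compounds shown here alone, it is also open whether chloro in place of cyano gives a readable step on the core of compound 1, which gives 21000 nM.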